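Thiosemicarbazones on a terpene core: pyrrole for methoxyphenyl

This account rests on a few compounds, and the source may have more. Where it says the series, first, only, none or still open, it means among the compounds named here.

Measured compounds:
- compound 1, `CC1=CC[C@H](C(C)(C)N=C=S)CC1`, > 100000 nM
- compound 2, `COc1ccc(/C=N/NC(=S)NC(C)(C)[C@H]2CC=C(C)CC2)cc1`, 1200 nM
- compound 3, `CC1=CC[C@H](C(C)(C)NC(=S)N/N=C/c2cccc([N+](=O)[O-])c2)CC1`, 88000 nM

All three share the same terpene-derived core and were tested in a functional assay on PC-3 cells (Homo sapiens) for inhibition, read by sulforhodamine B assay, with a stated time of 48 h; a higher number here means a weaker inhibitor of growth, a lower number a stronger inhibitor of growth. Compound 1 carries only the isothiocyanate; its reading of > 100000 nM is a limit of the assay, not a number (the limit of > 100000 nM in this assay, at which 1 of the 3 values shown sits). Among the two numbers obtained, compound 2 stands lowest at 1200 nM, while compound 3 with its nitrophenyl thiosemicarbazone gives 88000 nM, a gap well beyond the usual scatter.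

Compound 4, `CC1=CC[C@H](C(C)(C)NC(=S)N/N=C/c2ccc[nH]2)CC1`, is not yet measured. It differs from compound 2 by 1H-pyrrol-2-yl in place of 4-methoxyphenyl on a carbon with a double bond to nitrogen. Among the compounds with values here, no measured pair isolates such an exchange, so the direction rests only on the spread between compound 2 and compound 3, which shows that the aryl part of the thiosemicarbazone can move the reading far. The expectation is a weaker inhibitor of growth than compound 2, with the step from compound 2 to compound 4 estimated at a 6.7-fold higher number from compound 2 to compound 4 (0.82 log units; beyond the scatter). For compound 4 the estimated value in this assay is 8000 nM, within a range of 2000 nM to 40000 nM.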

Compound 4, concentration for total growth inhibition: > 100000 nM
Compound 4 was reported as a limit (the forecaster's own chance of this, stated with the estimate: 10%); at least 12-fold (1.09 log units) between middle value and limit.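

Within the data shown here, the exchange of 4-methoxyphenyl for 1H-pyrrol-2-yl on a carbon with a double bond to nitrogen is the first change in one place that can be read in this assay, and it gives an at least 83-fold higher number from compound 2 to compound 4 (1.92 log units; beyond the scatter). Compound 4 gives > 100000 nM, a limit of the assay and not a number, so the step fixes only a minimum size: the limit of > 100000 nM in this assay, at which 2 of the 4 values shown sit. With the rest of the thiosemicarbazone unchanged, the group at this place alone separates a measurable reading from a limit for this pair.

Among these compounds, whether the loss follows the five-membered ring or the ring nitrogen with its hydrogen stays open, as the one exchange changes both. Furan-2-yl and unsubstituted phenyl at this place would help separate the two.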